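The source may report more compounds than this note shows. Statements on the series, on what has been measured and on what is new or still open speak of the compounds shown alone.

Compound 1 `COC1=C(C)C(=O)/C(=C(O)/C=C/c2ccccc2C)C(=O)C1(C)C`: 2.3 ug/mL
Compound 2 `CCc1ccc(/C=C/C(O)=C2/C(=O)C(C)=C(OC)C(C)(C)C2=O)cc1`: "not determined" (no result reported)
Compound 3 `C=Cc1ccccc1/C=C/C(O)=C1/C(=O)C(C)=C(OC)C(C)(C)C1=O`: 1.1 ug/mL

In a functional assay on HUVEC cells (Homo sapiens) for cytotoxicity (on this read-out higher numbers stand for an effect only at larger amounts of compound and lower numbers for an effect already at smaller amounts), compound 3 gives 1.1 ug/mL, the lower of the two numbers available, while compound 2 offers no number for comparison. Next is compound 4 `COC1=C(C)C(=O)/C(=C(O)/C=C/c2nccs2)C(=O)C1(C)C`, with this change: 1,3-thiazol-2-yl in place of 2-vinylphenyl on a double-bonded chain carbon bound to a double-bonded chain carbon. Within the data shown here, only one measured step bears on it, a 2.1-fold lower number from compound 1 to compound 3 (0.32 log units; beyond the scatter). That step is modest and alters only a group on the aromatic ring, whereas here the whole ring is exchanged, so it is a weak guide. With compound 3 at the low end of a narrow range, a modest move towards a higher number is expected, and the expected step is a 2.3-fold higher number from compound 3 to compound 4 (0.36 log units; beyond the scatter). For compound 4 the estimated value is 2.5 ug/mL, with an expected range of 0.7 ug/mL to 9 ug/mL.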

Compound 4, concentration for half-maximal effect: 1.6 ug/mL
Compound 4: the middle estimate sits 1.6-fold (0.19 log units) above what was measured, and the stated range covers the measured number.
By their numbers in this assay, from the lowest: compounds 3, 4 and 1 (each within the scatter of the next, the first and the last beyond it).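

In this assay, the step of a 1.5-fold higher number from compound 3 to compound 4 (0.16 log units; within the scatter) and the step of a 1.4-fold lower number from compound 1 to compound 4 (0.16 log units; within the scatter) both lie within the scatter, so 1,3-thiazol-2-yl cannot be told apart from either 2-vinylphenyl or 2-methylphenyl at this place. The earlier compounds shown here showed only a change of substituent on the six-membered ring, whereas this position also tolerates exchange of that whole ring for a five-membered aromatic ring with 2 hetero atoms. No measured evidence explains this tolerance. Going by these compounds, it remains open whether an amine or a carboxylic acid at this place would keep the read-out in the same range.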